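Chromanol amines: phenethyl to dimethylamino at the chain end

The compounds below may be only part of what the source reports. "The series", "measured", "known", "first", "only" and "open" are said of these compounds alone.

Measured so far:
compound 1, `Cc1c(C)c2c(c(C)c1O)CCC(C)(CNc1ccccn1)O2`, 200 nM
compound 2, `Cc1c(C)c2c(c(C)c1O)CCC(C)(CNCCCCc1ccccc1)O2`, 800 nM

In a functional assay (brain) for inhibition, with Rattus norvegicus as the target (a lower number here means a stronger inhibitor, a higher number a weaker inhibitor), compound 1 gives 200 nM, and in the same assay compound 2 gives 800 nM. Of the two numbers compound 2 carries the higher one, so it is the weaker inhibitor of the pair, and the gap to compound 1 lies beyond the scatter. Among the compounds with values here, no pair differing in a single place has been measured, so no step size is established.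

Compound 3, `Cc1c(C)c2c(c(C)c1O)CCC(C)(CNCCN(C)C)O2`, is the next member. The change from compound 2 is dimethylamino in place of phenethyl on a saturated chain carbon, two bonds along the chain from an amine nitrogen. Within the data shown here, with no measured step to lean on, the expected change in this assay from compound 2 to compound 3 is no change at the digits printed from compound 2 to compound 3 (within the scatter), which is taken as none beyond the scatter. Compound 3 is therefore estimated at 800 nM, with a range of 300 nM to 2500 nM.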

Compound 3, half-maximal inhibitory concentration: 1700 nM
Compound 3: the middle estimate sits 2.1-fold (0.33 log units) below what was measured, within the range that was stated.
By their numbers in this assay, from the lowest: compound 1; then compound 2; then compound 3.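

In this assay, the change from phenethyl to dimethylamino gives the first step read at this place on the chain, a 2.1-fold higher number from compound 2 to compound 3 (0.33 log units; beyond the scatter), so a chain end with no aromatic ring still gives a measurable inhibitor, though a weaker one. Setting 2-(dimethylamino)ethyl in place of pyridin-2-yl on the amine nitrogen gives an 8.5-fold higher number from compound 1 to compound 3 (0.93 log units; beyond the scatter), and with both steps beyond the scatter, compound 3 is the weakest of the three in this assay. Nothing measured here accounts for either step.

Open, as far as these compounds go, is whether the loss at the chain end tracks the departing aromatic ring or the entering nitrogen, as the two change together from compound 2 to compound 3. A propyl group on the same chain carbon would help to separate these two readings.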